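Adding a nitro group to compound 3

The source may hold more compounds than are shown below. What is called first, only, known or untested is meant among the compounds shown, and "the series" means these compounds.

Of the compounds shown here, three sharing one core have so far been measured in a physicochemical assay for metabolic stability, at 30 degrees C, at pH 6.5 (on this read-out lower numbers stand for a shorter-lived compound and higher numbers for a longer-lived compound), as a guide to how long they last. Compound 3 `Nc1ncnc2c1ncn2[C@@H]1O[C@@H]2CO[P@](=O)(OCc3ccccc3)O[C@H]2[C@H]1O` gives 9.5 h and stands level with compound 2 `Nc1ncnc2c1ncn2[C@@H]1O[C@@H]2CO[P@](=O)(OCc3ccc([N+](=O)[O-])cc3)O[C@H]2[C@H]1O` at 9.5 h while compound 1 `Nc1ncnc2c1ncn2[C@@H]1O[C@@H]2CO[P@@](=O)(OCc3ccccc3)O[C@H]2[C@H]1O` gives the clearly lower 3 h in this assay.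

The next structure is compound 4 `Nc1ncnc2c1ncn2[C@@H]1O[C@@H]2CO[P@](=O)(OCc3ccccc3[N+](=O)[O-])O[C@H]2[C@H]1O` which departs from compound 3 by one change: nitro in place of hydrogen on an aromatic carbon. This nitro in place of hydrogen turns benzyl into 2-nitrobenzyl, ortho to a large group.

Two measured steps could bear on this. The larger, a 3.2-fold higher number from compound 1 to compound 3 (0.50 log units; beyond the scatter), comes with the fact that compounds 1 and 3 differ only in the configuration as drawn and involves no nitro, and compound 4 is drawn at phosphorus as compound 3 is, so it offers little guidance here. The more relevant step, no change at the digits printed from compound 2 to compound 3 (within the scatter), exchanges nitro and hydrogen on an aromatic carbon, although compound 2 does not hold its nitro ortho to a large group. That single comparison leaves real uncertainty about the new placement.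

The expected step is a 1.2-fold lower number from compound 3 to compound 4 (0.07 log units; within the scatter) and nothing beyond the scatter is anticipated. Compound 4 is estimated at 8 h with an expected range from 4 h to 16 h in this assay.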

Compound 4, half-life: 9.5 h
Estimate against measurement, compound 4: 1.2-fold (0.07 log units) below; the range from low to high includes it.
By their numbers in this assay, from the lowest: compound 1; then compounds 2, 3 and 4 (each within the scatter of the next).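

In this assay, nitro in place of hydrogen, now ortho to a large group, gives no change at the digits printed from compound 3 to compound 4 (within the scatter), so this new placement shows no effect on half-life that can be told from the scatter. Within the data shown here, until now the only nitro compound carried a 4-nitrophenyl, and the comparison of the two placements gives no change at the digits printed from compound 2 to compound 4 (within the scatter), so 2-nitrophenyl and 4-nitrophenyl cannot be told apart on this read-out, at least with the phosphorus drawn as in compound 3. No measurement shown here explains why the number holds steady across these changes.

The compounds shown carry only hydrogen or nitro on this aromatic ring, so it remains open whether an amine or a carboxylic acid in the same place would also leave the half-life where it stands. Going by these compounds, compounds 2, 3 and 4 all share one configuration at phosphorus, so it is also open whether a nitro group would leave the number unchanged on the configuration of compound 1, which gives 3 h on its own.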